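The source may report more compounds than this note shows. Statements on the series, on what has been measured and on what is new or still open speak of the compounds shown alone.

Measured so far:
compound 1, `CCOC(=O)CNn1c(C)nc2ccc(Br)cc2c1=O`: 20%
compound 2, `COc1ccc(/C=N/c2nnc(CNn3c(C)nc4ccc(Br)cc4c3=O)s2)cc1`: 50%
compound 3, `CCOC(=O)CNn1c(C)nc2ccccc2c1=O`: 20%

In a functional assay on the whole organism (strain albino) with Rattus norvegicus as the target, in the maximal electroshock model, with a stated time of 1 h, at a dose of 30 mg/kg by the intraperitoneal route (a higher number here means more inhibition at the dose given (going by the name of the read-out), a lower number less inhibition), compound 2 gives 50%, the highest of the three numbers; compound 1 with 20% and compound 3 with 20% both lie lower, by a gap beyond the scatter. How the core of compound 2 differs from the core of compound 1 is not broken down here.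

Compound 1 and compound 3 differ in one place: hydrogen in place of bromo on an aromatic carbon. Across that change, no change at the digits printed from compound 1 to compound 3 (within the scatter).

Compound 4, `COc1ccc(/C=N/c2nnc(CNn3c(C)nc4ccccc4c3=O)s2)cc1`, is not yet measured in this assay. It stands to compound 2 as compound 3 stands to compound 1: hydrogen in place of bromo on an aromatic carbon. The place of the change is described in the same words in both pairs, so this is the same change, made twice among the compounds shown.

The expectation for compound 4 rests on compound 1, where this change gave no change at the digits printed from compound 1 to compound 3 (within the scatter). Compound 4 is therefore expected to give about 45% in this assay, between 25% and 65%. The expected step is a number 5 percentage points lower from compound 2 to compound 4 (within the scatter), which is expected to stay within the scatter.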

Compound 4, a percentage reported as inhibition, in the whole organism at one dose (the size of the read-out at that dose, not a potency): 50%
Beside the measured number, compound 4's estimate is 5 percentage points below it; measured number inside the range.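

In this assay, hydrogen in place of bromo on an aromatic carbon gives no change at the digits printed from compound 2 to compound 4 (within the scatter), and this step matches the earlier one: the same change on two cores in this assay, no change at the digits printed (within the scatter) from compound 1 to compound 3 and no change at the digits printed (within the scatter) from compound 2 to compound 4, 0 percentage points apart, within the scatter of two such steps. Within these two pairs, the change carries from one core to the other, and the bromo can be exchanged for hydrogen on either core with no step beyond the scatter. Among the compounds shown here, this does not show that the result extends to other cores, doses or read-outs, since it rests on only two pairs and on a percentage at a single dose, which is not a potency.

The compounds shown leave open what a chloro, an amine or a carboxylic acid would do on the same aromatic carbon, as only bromo and hydrogen are compared there. They also leave open whether a dose that gives a different level of inhibition would separate the bromo compounds from their hydrogen partners.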